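Exchanging Fluoro for Chloro on the Pendant Aryl Ring

This account rests on a few compounds, and the source may have more. Where it says the series, first, only, none or still open, it means among the compounds named here.

Compound 1 `CC1C(=O)N(C)c2cnc(Nc3ccc(S(N)(=O)=O)cc3)nc2N1C` gives 313 nM in an assay on Sf9 cells for inhibition of serine/threonine-protein kinase 4 (Homo sapiens), read by luminescence and ADP-Glo, with a stated time of 1 h, in the presence of a further agent that is not named here; a lower number here means a stronger inhibitor, a higher number a weaker inhibitor.
Compound 2 `CN1C(=O)C(CC2CC2)N(C)c2nc(Nc3ccc(S(N)(=O)=O)cc3)ncc21` gives 211 nM in this assay.
Compound 3 `CN1C(=O)C(c2cccc(F)c2)N(C)c2nc(Nc3ccc(S(N)(=O)=O)cc3)ncc21` gives 134 nM in this assay.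

Compound 3 holds the lowest number of the three: the step of a 2.3-fold lower number from compound 1 to compound 3 (0.37 log units; beyond the scatter) lies beyond the scatter, while a 1.6-fold lower number from compound 2 to compound 3 (0.20 log units; within the scatter) and a 1.5-fold lower number from compound 1 to compound 2 (0.17 log units; within the scatter) do not. Compound 4 `CN1C(=O)C(c2cccc(Cl)c2)N(C)c2nc(Nc3ccc(S(N)(=O)=O)cc3)ncc21` differs from compound 3 by chloro in place of fluoro on an aromatic carbon. Within the data shown here, no measured step exchanges one halogen for another; the steps that are known all alter the group on the saturated ring carbon and were small or modest. The step of a 1.2-fold lower number from compound 3 to compound 4 (0.09 log units; within the scatter) is therefore expected to stay within the scatter, with no clear direction. Compound 4 is estimated at 110 nM, between 50 nM and 250 nM.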

Compound 4, half-maximal inhibitory concentration: 989 nM
For compound 4 the middle estimate is 9.0-fold (0.95 log units) below the measured one; the whole stated range lies below it.
By their numbers in this assay, from the lowest: compounds 3, 2 and 1 (each within the scatter of the next, the first and the last beyond it); then compound 4.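

In this assay, among these compounds, the exchange of fluoro for chloro on the aromatic carbon gives a 7.4-fold higher number from compound 3 to compound 4 (0.87 log units; beyond the scatter), a larger step than any among the earlier compounds, all of which changed the group on the saturated ring carbon. So this single halogen exchange on the phenyl ring matters more than those earlier changes. An aryl group on the saturated ring carbon is also no advantage in itself: 3-chlorophenyl in place of cyclopropylmethyl gives a 4.7-fold higher number from compound 2 to compound 4 (0.67 log units; beyond the scatter), and in place of methyl gives a 3.2-fold higher number from compound 1 to compound 4 (0.50 log units; beyond the scatter).

The data shown offer no explanation for the gap between the two halogens. From the compounds shown here alone, how a plain phenyl, or a methoxy or nitrile at this place on the ring, would read remains open.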